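Cyclohexyl imidazopyridine series: aryl replacement at the bromo position

This account rests on a few compounds, and the source may have more. Where it says the series, first, only, none or still open, it means among the compounds named here.

Compound 3 `c1ccc2c(-c3cn4ccnc4c(-c4ccc5ncn(C6CCCCC6)c5c4)n3)cccc2c1` gives 6.33% in a functional assay on 786-0 cells (Homo sapiens) for inhibition, read by sulforhodamine B assay, with a stated time of 48 h, tested at 10 uM (a lower number here means less inhibition, a higher number more inhibition at the concentration tested (going by the name of the read-out)), the lowest of the three numbers in hand. Compound 1 `Brc1cn2ccnc2c(-c2ccc3ncn(C4CCCCC4)c3c2)n1` gives 10% and compound 2 `c1ccc(-c2cn3ccnc3c(-c3ccc4ncn(C5CCCCC5)c4c3)n2)cc1` gives 36.8%. Compound 3 stands within the scatter of compound 1 (a number 3.7 percentage points lower from compound 1 to compound 3 (within the scatter)) and beyond it of compound 2 (a number 30.5 percentage points lower from compound 2 to compound 3 (beyond the scatter)). Compound 4 `Fc1ccc(-c2cn3ccnc3c(-c3ccc4ncn(C5CCCCC5)c4c3)n2)cc1` carries the change (4-fluorophenyl in place of naphthalen-1-yl on an aromatic carbon). Apart from the added fluorine, this change largely runs a measured step backwards. That measured step (a number 30.5 percentage points lower from compound 2 to compound 3 (beyond the scatter)) went down, and the earlier step (a number 26.8 percentage points higher from compound 1 to compound 2 (beyond the scatter)) points the same way. A rise beyond the scatter is therefore expected, a number 25.7 percentage points higher from compound 3 to compound 4 (beyond the scatter), taking compound 4 to an estimated 32% with a range of 12% to 50%.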

Compound 4, a percentage reported as inhibition, at one concentration (the size of the read-out at that concentration, not a potency): 11.2%
Compound 4: middle estimate off by 20.8 percentage points, on the high side; measured number outside the range, below it.
By their numbers in this assay, from the lowest: compounds 3, 1 and 4 (each within the scatter of the next); then compound 2.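

At this position on the shared core, a single fluoro on the phenyl ring in compound 2 takes away nearly all that phenyl gained over bromo in this assay (a number 25.6 percentage points lower from compound 2 to compound 4 (beyond the scatter)). The 4-fluorophenyl group does not separate from naphthalen-1-yl (a number 4.9 percentage points higher from compound 3 to compound 4 (within the scatter)) or from bromo (a number 1.2 percentage points higher from compound 1 to compound 4 (within the scatter)), so among these four compounds only unsubstituted phenyl stands clear. Nothing at hand accounts for the drop on adding fluorine. Going by these compounds, whether the drop is particular to fluoro stays open, as does whether an amine or a methoxy group on that phenyl ring keeps the level of compound 2.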